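Isoflavone ether series: prenyl to nitrobenzyl step

This account rests on a few compounds, and the source may have more. Where it says the series, first, only, none or still open, it means among the compounds named here.

Measured compounds:
compound 1, `COc1cc(OC)c(-c2coc3cc(OCC=C(C)C)ccc3c2=O)cc1OC`: 1090 nM in a functional assay on B16 cells (Mus musculus) for antiproliferative activity, read by MTT assay, with a stated time of 24 h; on this read-out lower numbers stand for stronger inhibition and higher numbers for weaker inhibition
compound 2, `C=CCOc1ccc2c(=O)c(-c3cc(OC)c(OC)cc3OC)coc2c1`: 5100 nM in this assay
compound 3, `COc1cc(OC)c(-c2coc3cc(OCc4ccccc4F)ccc3c2=O)cc1OC`: 1610 nM in this assay

Compound 1 gives the lowest of the three numbers in this assay, with compound 3 within the scatter of it and compound 2 beyond it. The shared core is kept throughout; only the ether side chain varies. The steps among the measured compounds are a 4.7-fold higher number from compound 1 to compound 2 (0.67 log units; beyond the scatter), a 1.5-fold higher number from compound 1 to compound 3 (0.17 log units; within the scatter) and a 3.2-fold lower number from compound 2 to compound 3 (0.50 log units; beyond the scatter).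

Compound 4, `COc1cc(OC)c(-c2coc3cc(OCc4ccc([N+](=O)[O-])cc4)ccc3c2=O)cc1OC`, differs from compound 1 as follows: 4-nitrophenyl in place of 2-methylprop-1-en-1-yl on a saturated chain carbon bound to an oxygen on an aromatic ring. Within the data shown here, the nearest measured step is the one to compound 3, which also places a ring carrying a substituent on the saturated chain carbon bound to the oxygen on the aromatic ring and stays within the scatter. The step to compound 2, which shortens the chain to a vinyl, is the only one beyond the scatter. For compound 4 the expectation is therefore a step in this assay of a 1.7-fold higher number from compound 1 to compound 4 (0.22 log units; within the scatter), within or near the scatter, in the weaker direction if any. The estimated value for compound 4 in this assay is 1800 nM, with a range from 700 nM to 4500 nM.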

Compound 4, half-maximal inhibitory concentration: > 10000 nM
Compound 4 ended at the assay's limit (the forecaster's own chance of this, stated with the estimate: 5%); middle value at least 5.5-fold (0.74 log units) from the limit.
By their numbers in this assay, from the lowest: compounds 1 and 3 (each within the scatter of the next); then compound 2. At a limit, above all of these: compound 4.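

In this assay compound 4 gives > 10000 nM, which is a limit of the assay and not a number, so every step to it is a floor: the limit of > 10000 nM in this assay, at which 1 of the 4 values shown sits.

Among these compounds, on the saturated chain carbon bound to an oxygen on an aromatic ring, the earlier compounds allowed 2-fluorophenyl to stand in for 2-methylprop-1-en-1-yl within the scatter, but an aromatic ring there does not by itself keep the read-out, as the series gives an at least 6.2-fold higher number from compound 3 to compound 4 (0.79 log units; beyond the scatter) and an at least 9.1-fold higher number from compound 1 to compound 4 (0.96 log units; beyond the scatter). The third step, an at least 1.9-fold higher number from compound 2 to compound 4 (0.29 log units; that floor lies within the scatter), does not separate compound 4 from compound 2.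

From the compounds shown here alone, whether the loss follows the nitro group itself or its place on the ring remains open. A 2-nitrophenyl or 4-fluorophenyl group on the same carbon would help to separate these two readings.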